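Debromination of Indole Hydrazones Against Lung Cancer Cells

The source may hold more compounds than are shown below. What is called first, only, known or untested is meant among the compounds shown, and "the series" means these compounds.

Compound 1 `Cc1ccc(N2C(=O)CS/C2=N/N=C/c2c[nH]c3ccc(Br)cc23)cc1` was tested in a functional assay on NCI-H460 cells (Homo sapiens) for inhibition, read by spectrophotometry and sulforhodamine B assay, with a stated time of 48 h (on this read-out higher numbers stand for weaker inhibition of growth and lower numbers for stronger inhibition of growth), where compound 1 gives 96600 nM, the highest of the three measured numbers. Compound 2 `S=C(N/N=C/c1c[nH]c2ccc(Br)cc12)Nc1cccc2ccccc12` gives 6990 nM in this assay, and compound 3 `S=C(N/N=C/c1c[nH]c2ccccc12)Nc1cccc2ccccc12` gives 380 nM. Compound 2 and compound 3 differ by hydrogen in place of bromo on an aromatic carbon, a change that brought an 18-fold lower number from compound 2 to compound 3 (1.26 log units; beyond the scatter). The difference between the core of compound 1 and the core of compound 2 is not broken down here. Compound 4 `Cc1ccc(N2C(=O)CS/C2=N/N=C/c2c[nH]c3ccccc23)cc1` has not yet been measured; it differs from compound 1 by hydrogen in place of bromo on an aromatic carbon, the same change at the same place as that from compound 2 to compound 3. In this assay compound 4 is expected to give 20000 nM, between 5000 nM and 80000 nM. Among the compounds with values here, the expected step of a 4.8-fold lower number from compound 1 to compound 4 (0.68 log units; beyond the scatter) is estimated smaller than the earlier one, because the only precedent is an 18-fold lower number from compound 2 to compound 3 (1.26 log units; beyond the scatter) on a different core.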

Compound 4, concentration for 50% growth inhibition: > 100000 nM
Compound 4 gave a limit, no number (the forecaster's own chance of this, stated with the estimate: 5%); at least 5.0-fold (0.69 log units) between middle value and limit.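

In this assay compound 4 gives > 100000 nM, which is a limit of the assay and not a number. Hydrogen in place of bromo on the core of compound 1 gives an at least 1.0-fold higher number from compound 1 to compound 4 (0.01 log units; that floor lies within the scatter), so the gain seen on the core of compound 2 did not carry over: the same change on two cores in this assay, an 18-fold lower number (1.26 log units; beyond the scatter) from compound 2 to compound 3 and an at least 1.0-fold higher number (0.01 log units; that floor lies within the scatter) from compound 1 to compound 4, at least 19-fold (1.27 log units) apart, beyond the scatter of two such steps

The limit does not show how far compound 4 really lies from compound 1, or whether the two differ at all, and two cores give no rule for others: the limit of > 100000 nM in this assay, at which 1 of the 4 values shown sits.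

Going by these compounds, it remains open how a chloro or a methoxy group in the place of that bromo would behave on either core. The same holds for an amine at that place.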